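The source may hold more compounds than are shown below. What is called first, only, known or untested is meant among the compounds shown, and "the series" means these compounds.

Three compounds share one core, and they differ only in the group hanging from it. Compound 1 `O=c1cc(Cn2cc(CCc3ccccc3)nn2)c2ccc(O)cc2o1` carries a phenylethyl side group, and compound 2 `O=c1cc(Cn2cc(CNS(=O)(=O)c3ccc(F)cc3Cl)nn2)c2ccc(O)cc2o1` a sulfonamide bearing a halogenated phenyl ring. In a functional assay on CFPAC-1 cells (Homo sapiens) for inhibition, read by MTT assay, with a stated time of 72 h (on this read-out lower numbers stand for stronger inhibition and higher numbers for weaker inhibition), compound 1 gives > 100000 nM, which is a limit of the assay and not a number. In this assay compound 2 likewise reaches only > 100000 nM, again a limit. Among the measured compounds shown here, compound 3 `Cc1ccc2nc(-c3ccc(NCc4cn(Cc5cc(=O)oc6cc(O)ccc56)nn4)cc3)sc2c1`, whose side group is an aminomethyl link to a phenyl ring that carries a further aromatic substituent, gives 10500 nM in this assay, and this is the only measured number among the three. The other two readings correspond to the limit of > 100000 nM in this assay, at which 2 of the 3 values shown sit. Compound 4 `Cc1ccc2c(Cn3cc(CNc4ccc(-c5nc6ccc(C)cc6s5)cc4)nn3)cc(=O)oc2c1` differs from compound 3 in one place: methyl in place of hydroxy on an aromatic carbon. For the measured compounds named here, no step between two measured compounds is available to calibrate this change, so only a modest shift is expected, toward weaker inhibition if any, and perhaps none beyond the usual scatter. For compound 4 the expected value is 15000 nM, with a range from 4000 nM to 60000 nM, which amounts to an estimated step of a 1.4-fold higher number from compound 3 to compound 4 (0.15 log units; within the scatter).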

Compound 4, half-maximal inhibitory concentration: 34900 nM
For compound 4 the middle estimate is 2.3-fold (0.37 log units) below the measured one; low and high end bracket the measured number.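

Among the compounds shown here, this is the first view of this aromatic carbon, because compounds 1, 2 and 3 all carry hydroxy there, so their differences lay only in the side group. Putting methyl in place of hydroxy gives a 3.3-fold higher number from compound 3 to compound 4 (0.52 log units; beyond the scatter), which means weaker inhibition, so this place on the shared core matters in this assay and not only the side group does. Even so, compound 4 still reads as a measured number and does not sit at the limit of the assay: the limit of > 100000 nM in this assay, at which 2 of the 4 values shown sit.

On these data alone, this single pair cannot say whether the loss of the hydroxy or the arrival of the methyl drives the step, and how a methoxy group or an amine on the same carbon would read stays open. As far as these compounds go, whether the step would hold with other side groups also remains unknown.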